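Replacing Fluoro with Ethoxy: What the Numbers Suggest

The source may report more compounds than this note shows. Statements on the series, on what has been measured and on what is new or still open speak of the compounds shown alone.

Three amides sharing one core have been tested. In a functional assay on A-375 cells (Homo sapiens) for antiproliferative activity, read by MTT assay, with a stated time of 24 h, tested at 100 ug/mL (a higher number here means a stronger effect of the compound at the concentration tested, a lower number a weaker effect), compound 1 `CCOc1ccc2nc(C(=O)Nc3c(F)cc(-c4cccc(F)c4)cc3F)c(C)c(O)c2c1` gives 37.9%, compound 2 `Cc1ccc2nc(C(=O)Nc3c(F)cc(-c4cccc(F)c4)cc3F)c(C)c(C(=O)O)c2c1` gives 37.3%, and compound 3 `Cc1c(C(=O)Nc2c(F)cc(-c3cccc(F)c3)cc2F)nc2ccc(F)cc2c1C(=O)O` gives 64.3%. Compound 3 stands highest of the three; compound 1 and compound 2 both lie more than a scatter-width below it. For the measured compounds named here, the only single-point step measured so far is a number 27 percentage points higher from compound 2 to compound 3 (beyond the scatter), which is a fluoro in place of methyl on an aromatic carbon.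

Compound 4 `CCOc1ccc2nc(C(=O)Nc3c(F)cc(-c4cccc(F)c4)cc3F)c(C)c(C(=O)O)c2c1` has not been measured. It differs from compound 3 as follows: ethoxy in place of fluoro on an aromatic carbon. Going by the values given here, this touches the same aromatic carbon as the measured step, but in a new way: no pair of compounds shows fluoro against ethoxy directly. What the data do show is that compound 1, which also carries ethoxy, gives 37.9%, and compound 2 with methyl gives 37.3%, both well under compound 3. The expected step is therefore a modest fall, estimated as a number 19.3 percentage points lower from compound 3 to compound 4 (beyond the scatter). Compound 4 is estimated to give 45% in this assay, with a range from 28% to 62%.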

Compound 4, a percentage reported as inhibition, at one concentration (the size of the read-out at that concentration, not a potency): 72.4%
Estimate against measurement, compound 4: 27.4 percentage points below, and the stated range ends below it.
By their numbers in this assay, from the lowest: compounds 2 and 1 (each within the scatter of the next); then compounds 3 and 4 (each within the scatter of the next).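

In this assay the swap of fluoro for ethoxy on this aromatic carbon makes no clear difference (a number 8.1 percentage points higher from compound 3 to compound 4 (within the scatter)), even though ethoxy brings three heavy atoms where fluoro brings one, so among these groups a larger one is accepted here. Methyl is the group that stands apart at this carbon, as putting ethoxy in its place gives a large rise (a number 35.1 percentage points higher from compound 2 to compound 4 (beyond the scatter)), and the low reading of compound 1 cannot be blamed on its ethoxy, as the same ethoxy is kept while carboxy replaces hydroxy and the number again rises sharply (a number 34.5 percentage points higher from compound 1 to compound 4 (beyond the scatter)). Nothing available explains any of these steps.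

Going by these compounds, whether a longer chain such as butoxy, or an amine, would fare like ethoxy and fluoro on this aromatic carbon remains open. On these data alone, each reading is also the size of the effect at a single concentration, so how compound 3 and compound 4 compare at other concentrations remains open too.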